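This account rests on a few compounds, and the source may have more. Where it says the series, first, only, none or still open, it means among the compounds named here.

Compound 1 `COc1cc(-c2cc(/C=C/C(=O)c3ccc(Cl)c(Cl)c3)[nH]n2)cc(OC)c1OC` is the weaker of the two measured compounds in a functional assay on ACHN cells (Homo sapiens) for inhibition, read by sulforhodamine B assay, with a stated time of 48 h; on this read-out lower numbers stand for stronger inhibition of growth and higher numbers for weaker inhibition of growth: compound 1 gives 21400 nM, the highest of the two numbers, while compound 2 `COc1ccc(-c2cc(/C=C/C(=O)c3cc(OC)c(OC)c(OC)c3)[nH]n2)cc1OC` gives 1450 nM, a gap that lies beyond the scatter. Compound 3 `COc1cc(-c2cc(/C=C/C(=O)c3ccc(F)c(F)c3)[nH]n2)cc(OC)c1OC` has not yet been measured. It differs from compound 1 in one place: 3,4-difluorophenyl in place of 3,4-dichlorophenyl on a carbonyl carbon. For the measured compounds named here, no measured pair shows this change, so its effect is unknown; the expected step from compound 1 to compound 3 in this assay is a 1.3-fold lower number from compound 1 to compound 3 (0.13 log units; within the scatter), small and within the scatter. Compound 3 is therefore expected to give about 16000 nM, between 5000 nM and 50000 nM.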

Compound 3, concentration for 50% growth inhibition: 3260 nM
Compound 3: the middle estimate sits 4.9-fold (0.69 log units) above what was measured; the whole stated range lies above it.
By their numbers in this assay, from the lowest: compound 2; then compound 3; then compound 1.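

In this assay, 3,4-difluorophenyl in place of 3,4-dichlorophenyl on a carbonyl carbon gives a 6.6-fold lower number from compound 1 to compound 3 (0.82 log units; beyond the scatter), so this position responds to the choice of halogen. The step comes with no change in the counted heavy atoms, hydrogen-bond donors or hydrogen-bond acceptors of the group. Nothing at hand accounts for this step. The compounds shown leave open whether both fluorine atoms are needed, and how a plain phenyl group or an aminophenyl group would behave at this place.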